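Replacing 1H-imidazol-2-yl in compound 2

A few compounds are considered here, and "the series" means these few. Any claim that something is new, unique, unknown or untested is made for them only; others in the source may bear on it.

Measured in an ADME assay on a cell-free system (plasma, Homo sapiens) for protein binding; a higher number here means a larger unbound share of the compound, a lower number a smaller unbound share:
- Compound 1 `Cc1ccc(-c2cnc(C)n2C)cc1NC(=O)c1ccc(OCc2ccccn2)cc1`: 0.19
- Compound 2 `Cc1cc(C)c(-c2ncc[nH]2)cc1NC(=O)c1ccc(OCc2ccccn2)cc1`: 0.067
- Compound 3 `Cc1cc(F)c(-c2ncc[nH]2)cc1NC(=O)c1ccc(OCc2ccccn2)cc1`: 0.11

Compound 2 sits at the low end of this small set, clearly apart from compound 1 but not from compound 3. Compound 4 `Cc1cc(C)c(-c2c[nH]nc2C)cc1NC(=O)c1ccc(OCc2ccccn2)cc1` alters compound 2 in one place: 3-methyl-1H-pyrazol-4-yl in place of 1H-imidazol-2-yl on an aromatic carbon. Among the measured compounds shown here, the only measured single change is a 1.6-fold higher number from compound 2 to compound 3 (0.22 log units; within the scatter). It swaps fluoro for methyl and leaves the 1H-imidazol-2-yl in place, so it offers only a rough guide to step size. Compound 1 differs from compound 2 in more than one place. No shift beyond the scatter is therefore expected in this assay. The expected change is a 1.0-fold higher number from compound 2 to compound 4 (0.02 log units; within the scatter). For compound 4 the estimated value is 0.07, with an expected range of 0.04 to 0.13.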

Compound 4, unbound fraction: 0.021
For compound 4 the middle estimate is 3.3-fold (0.52 log units) above the measured one; the measured number lies below the stated range.
By their numbers in this assay, from the lowest: compound 4; then compounds 2, 3 and 1 (each within the scatter of the next, the first and the last beyond it).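

In this assay, this position proved sensitive to the choice of five-membered ring: a 3.2-fold lower number from compound 2 to compound 4 (0.50 log units; beyond the scatter). The swap keeps the ring size, the hydrogen-bond donor and acceptor counts and the absence of net charge, so a change that leaves those counts alone can still shift the unbound share. The data available offer no explanation for this shift. Still open, going by these compounds, is whether the lower number follows the ring itself or its methyl, which a 1H-pyrazol-4-yl without that methyl could separate. Also open, on these data alone, is how a carboxylic acid or an amine would read at this position.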